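The source may hold more compounds than are shown below. What is called first, only, known or untested is meant among the compounds shown, and "the series" means these compounds.

The measured compounds and their values:

compound 1, `Cn1c(-c2ccc([N+](=O)[O-])cc2)nc2cc(C(F)(F)F)ccc21`: > 100000 nM
compound 2, `CC(=O)Nc1ccc(-c2nc3cc(C(F)(F)F)ccc3n2C)cc1`: > 100000 nM
compound 3, `CC(=O)Nc1ccc(-c2nc3cc(C(F)(F)F)ccc3n2C2CCCCC2)cc1`: 30000 nM

In an ADME assay on Vero cells (Chlorocebus sabaeus) for cytotoxicity (on this read-out lower numbers stand for higher toxicity in this test and higher numbers for lower toxicity in this test), compound 1 gives > 100000 nM, which is a limit of the assay and not a number. Compound 2 likewise gives only a limit, > 100000 nM. For the measured compounds named here, compound 3 is the one compound here that gives a number, 30000 nM.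

The change from compound 2 to compound 1 is nitro in place of acetamido on an aromatic carbon, and its step in this assay is a step that the two limits leave unreadable from compound 2 to compound 1; this is because of the limit of > 100000 nM in this assay, at which 2 of the 3 values shown sit. The change from compound 2 to compound 3 is cyclohexyl in place of methyl on an aromatic nitrogen, and in this assay it gives an at least 3.3-fold lower number from compound 2 to compound 3 (0.52 log units; beyond the scatter).

Compound 4, `O=[N+]([O-])c1ccc(-c2nc3cc(C(F)(F)F)ccc3n2C2CCCCC2)cc1`, has not yet been measured. It differs from compound 3 by nitro in place of acetamido on an aromatic carbon, the same change that leads from compound 2 to compound 1. The two cores differ by cyclohexyl in place of methyl on an aromatic nitrogen. The earlier step could not be read, so it offers no guidance on size. In this assay the step from compound 3 to compound 4 is expected to be no change at the digits printed from compound 3 to compound 4 (within the scatter), resting on the number of compound 3, 30000 nM, as the only anchor. For compound 4 the estimate is 30000 nM, expected to fall between 10000 nM and 100000 nM.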

Compound 4, half-maximal cytotoxic concentration: > 100000 nM
Compound 4: no number, only a limit (the forecaster's own chance of this, stated with the estimate: 25%); middle value at least 3.3-fold (0.52 log units) from the limit.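

On the core that carries cyclohexyl, nitro in place of acetamido gives an at least 3.3-fold higher number from compound 3 to compound 4 (0.52 log units; beyond the scatter) in this assay. Compound 4 gives > 100000 nM, which is a limit of the assay and not a number, so the step shows a minimum size and not a true one. The same change on the core that carries methyl cannot be read, and neither can the step from methyl to cyclohexyl between the two nitro compounds, so the compounds show no size on one core that could be set against the other and do not show whether the change acts alike on both: the limit of > 100000 nM in this assay, at which 3 of the 4 values shown sit.

From the compounds shown here alone, only compound 3 gives a number, 30000 nM, so it remains open how an amine or a carboxylic acid in place of acetamido would read on the core of compound 3. It also remains open whether the lower number seen with an at least 3.3-fold lower number from compound 2 to compound 3 (0.52 log units; beyond the scatter) would appear with an ethyl or isopropyl group on the aromatic nitrogen, since only methyl and cyclohexyl stand there in the compounds shown.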